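The source may hold more compounds than are shown below. What is called first, only, known or untested is meant among the compounds shown, and "the series" means these compounds.

The compounds here share one core, carried on compound 3 `Cc1cn(C2CCN(Cc3cccc(Oc4ccccc4)c3)CC2)c(=O)[nH]c1=O`, which bears a plain phenoxy group. Within the data shown here, in an ADME assay on MRC5 cells (Homo sapiens) for cytotoxicity, read by fluorescence and resazurin assay, with a stated time of 3 days (on this read-out lower numbers stand for stronger inhibition and higher numbers for weaker inhibition), compound 3 has no result at all, "not determined" (no result reported); it is the only member of the set without a value. Its two close relatives set the background. Compound 1 `Cc1cn(C2CCN(Cc3cccc(Oc4cc(F)cc(F)c4)c3)CC2)c(=O)[nH]c1=O` returns in this assay only a limit, > 64000 nM. Compound 2 `Cc1cn(C2CCN(Cc3cccc(Oc4ccc(F)c(F)c4)c3)CC2)c(=O)[nH]c1=O` likewise returns only a limit, > 64000 nM. Among the measured compounds shown here, the one measured step, a step that the two limits leave unreadable from compound 1 to compound 2, therefore cannot be read in size, because both of its ends rest at the limit of > 64000 nM in this assay, at which 2 of the 3 values shown sit. The change to compound 4 `COc1ccc(Oc2cccc(CN3CCC(n4cc(C)c(=O)[nH]c4=O)CC3)c2)cc1` is methoxy in place of hydrogen on an aromatic carbon. For the measured compounds named here, no measured step touches a methoxy group, so nothing among the three compounds speaks for a shift in either direction beyond the usual scatter; what the set does show is that two near relatives of compound 3 both sit at the limit of this assay, as captured in the limit of > 64000 nM in this assay, at which 2 of the 3 values shown sit. On that footing compound 4 is expected to show no measurable cytotoxicity either, with an estimated value of 80000 nM in this assay, spanning 30000 nM to 200000 nM, and most probably reported once more only as a limit.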

Compound 4, half-maximal inhibitory concentration: 28000 nM
The estimate for compound 4 lay 2.9-fold (0.46 log units) above the measured number; the measured number lies below the stated range.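

Among these compounds, compound 4 is the first compound in this set to give an actual number in this assay: compound 4 gives 28000 nM. A substituted phenoxy group on this core can therefore leave a readable effect on these cells, and swapping the fluorines for a single methoxy group para to a large group produces an at least 2.2-fold lower number from compound 2 to compound 4 (0.35 log units; beyond the scatter) and an at least 2.2-fold lower number from compound 1 to compound 4 (0.35 log units; beyond the scatter), both pointing towards stronger inhibition. These two steps give only the smallest possible size of the change, and the true gap could be wider, because compound 1 and compound 2 each rest at a limit rather than a number: the limit of > 64000 nM in this assay, at which 2 of the 4 values shown sit.

On these data alone, with no result for compound 3, the plain phenoxy parent offers no reference point, so it remains unknown whether the methoxy group raises the effect or the fluorines suppress it, and the step between compound 1 and compound 2 cannot be read. As far as these compounds go, it also remains open whether the effect depends on this particular group or would be matched at the same place by an amine, a carboxylic acid or a longer chain such as ethoxy.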